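The compounds below may be only part of what the source reports. "The series", "measured", "known", "first", "only" and "open" are said of these compounds alone.

Measured compounds:
Compound 1, `Cc1ccc(C)n1-c1ccc(C(=O)N/N=C/c2ccc(N(C)C)cc2)cc1` — "not determined" (no result reported)
Compound 2, `O=[N+]([O-])c1ccccc1-c1nnc(-c2ccc(-n3cccc3)cc2)o1` — 266000 nM
Compound 3, `CC(=O)N1N=C(c2ccc(-n3c(C)ccc3C)cc2)OC1c1ccccc1[N+](=O)[O-]` — 175000 nM

Three compounds share a common aryl-pyrrole motif attached to a carbonyl-bearing or heterocyclic linker. For compound 1, an ADME assay on Vero cells (Chlorocebus sabaeus) for cytotoxicity, read by MTT assay, with a stated time of 72 h (on this read-out lower numbers stand for stronger inhibition and higher numbers for weaker inhibition), returned "not determined" (no result reported). In this assay compound 2 gives 266000 nM and compound 3 gives 175000 nM. Compound 3 therefore carries the lowest of the two numbers, but its gap to compound 2 lies within the scatter, so the two cannot be told apart on these data.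

The step under consideration leads from compound 3 to compound 4, `CC(=O)N1N=C(c2ccc(-n3c(C)ccc3C)cc2)OC1c1ccccc1`, by a single change: hydrogen in place of nitro on an aromatic carbon. Among the measured compounds shown here, no step between two measured compounds is available to calibrate this change, and neither compound 2 nor compound 3 offers a matched pair for it. With both measured numbers sitting close together and very weak, the expectation for compound 4 is a step of a 1.1-fold higher number from compound 3 to compound 4 (0.06 log units; within the scatter) that stays within the scatter, with no clear direction. On that basis compound 4 is expected to give about 200000 nM in this assay, with a plausible range from 80000 nM to 500000 nM.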

Compound 4, half-maximal inhibitory concentration: 190000 nM
Estimate against measurement, compound 4: 1.1-fold (0.02 log units) above; the range from low to high includes it.
By their numbers in this assay, from the lowest: compounds 3, 4 and 2 (each within the scatter of the next).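

In this assay, among the compounds shown here, hydrogen in place of nitro on this aromatic carbon, the change from 2-nitrophenyl to phenyl, gives a 1.1-fold higher number from compound 3 to compound 4 (0.04 log units; within the scatter) as the first direct reading at this position, which the earlier compounds could not provide. The nitro group, on a six-membered aromatic ring of carbon only and ortho to a large group, can therefore be replaced by hydrogen with a step that stays within the scatter on this read-out. Nothing measured here bears on why the step is this size.

On these data alone, whether an amine, a carboxylic acid or a methoxy group on the same aromatic carbon would also stay within the scatter remains open. So does whether the change from 2-nitrophenyl to phenyl would read the same on the core of compound 2.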